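A few compounds are considered here, and "the series" means these few. Any claim that something is new, unique, unknown or untested is made for them only; others in the source may bear on it.

Compound 2 `Cc1nc(S(C)(=O)=O)ccc1Oc1ncnc(OC2CCN(C(=O)SC(C)C)CC2)c1F` gives 41.3 nM in a functional assay on isolated protein for inhibition of Glucose-dependent insulinotropic receptor (Rattus norvegicus), read by HTRF and cAMP accumulation (a lower number here means that less compound is needed, a higher number that more compound is needed for the effect), the lower of the two numbers measured; compound 1 `Cc1nc(S(C)(=O)=O)ccc1Oc1ncnc(OC2CCN(C(=O)O[C@@H](C)C(F)(F)F)CC2)c1F` gives 109 nM. Going by the values given here, the one measured step, a 2.6-fold lower number from compound 1 to compound 2 (0.42 log units; beyond the scatter), changed the group on the carbonyl carbon. Compound 3 `Cc1nc(S(C)(=O)=O)ccc1Oc1ncnc(OC2CCN(C(=O)SC3(C)CC3)CC2)c1F` differs from compound 2 by 1-methylcyclopropyl in place of isopropyl on a sulfur. This is a smaller alteration than the measured step, which exchanged the atom bonded to the carbonyl carbon, so no step beyond the scatter is expected: a 1.2-fold lower number from compound 2 to compound 3 (0.07 log units; within the scatter). Compound 3 is therefore expected to give about 35 nM, with a range from 15 nM to 90 nM.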

Compound 3, half-maximal effective concentration: 166 nM
Beside the measured number, compound 3's estimate is 4.7-fold (0.68 log units) below it; the whole stated range lies below it.
By their numbers in this assay, from the lowest: compound 2; then compounds 1 and 3 (each within the scatter of the next).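

With a 4.0-fold higher number from compound 2 to compound 3 (0.60 log units; beyond the scatter) the swap of isopropyl for 1-methylcyclopropyl on the sulfur shows that a change confined to this small carbon group is enough to move the number beyond the scatter. With a 1.5-fold higher number from compound 1 to compound 3 (0.18 log units; within the scatter) the two compounds cannot be told apart, so sulfur on the carbonyl carbon does not by itself bring the lower number of compound 2. No measurement at hand gives a reason for this step. On these data alone, it remains open whether the ring or the added carbon matters, which cyclopropyl or tert-butyl on the sulfur could help to separate.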